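This account rests on a few compounds, and the source may have more. Where it says the series, first, only, none or still open, it means among the compounds named here.

Measured in a functional assay on PC-3 cells (Homo sapiens) for inhibition, read by sulforhodamine B assay, with a stated time of 48 h, tested at 50 uM; a higher number here means more inhibition of growth at the concentration tested, a lower number less inhibition of growth:
- Compound 1 `COc1cc(/C=C/C(=O)/C=C/c2cccc3ccccc23)ccc1OCc1cn(CCCCCOc2cc(=O)oc3ccccc23)nn1`: "not active" (no number reported)
- Compound 2 `COc1cc(/C=C/C(=O)/C=C/c2cccs2)ccc1OCc1cn(CCOc2cc(=O)oc3ccccc23)nn1`: 12%
- Compound 3 `COc1cc(/C=C/C(=O)/C=C/c2cc(OC)c(OC)c(OC)c2)ccc1OCc1cn(CCOc2cc(=O)oc3ccccc23)nn1`: 22%

Compound 1 has no place on the numerical scale: in this assay compound 1 is reported as "not active" (no number reported). It therefore offers no number from which a step can be counted.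

The next compound to be tested is compound 4 `COc1cc(/C=C/C(=O)/C=C/c2cc(OC)c(OC)c(OC)c2)ccc1OCc1cn(CCCCCOc2cc(=O)oc3ccccc23)nn1`. The change from compound 1 is 3,4,5-trimethoxyphenyl in place of naphthalen-1-yl on a double-bonded chain carbon bound to a double-bonded chain carbon, which in words is 3,4,5-trimethoxyphenyl in place of naphthalen-1-yl on a double-bonded chain carbon bound to a double-bonded chain carbon.

Among the compounds with values here, only one measured step brings in the same group, and it replaces thiophen-2-yl rather than naphthalen-1-yl: a number 10 percentage points higher from compound 2 to compound 3 (within the scatter). Within the data shown here, this single step is small, and no measured step starts from naphthalen-1-yl. No number yet exists for any compound with the core of compound 1, so the estimate remains loose.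

The data give no reason to expect a large gain from this swap. At most, a modest reading may replace the result without a number, in the low range seen for compound 2 and compound 3. Compound 4 is expected to give about 15%, with an estimated range from 3% to 32%.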

Compound 4, percent growth inhibition at one concentration: "not active" (no number reported)
The entry for compound 4 holds no number; there is nothing to compare the estimate with.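

In this assay compound 1 gives "not active" (no number reported) and compound 4 gives "not active" (no number reported) so neither offers a number, and no step can be read between them. The compounds shown leave open how naphthalen-1-yl and 3,4,5-trimethoxyphenyl compare on the core of compound 1. No measured evidence bears on these two results.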